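The source may report more compounds than this note shows. Statements on the series, on what has been measured and on what is new or still open speak of the compounds shown alone.

Measured compounds:
- compound 1, `Cc1ccc2c(NCc3ccc(NC(=O)C4CCN(C5CCCCC5)CC4)cc3)nc(N(C)C)nc2c1`; in a functional assay on SV5A8 cells (Homo sapiens) for cytotoxicity (a higher number here means a weaker inhibitor, a lower number a stronger inhibitor), compound 1 gives only a limit, > 8320 nM
- compound 2, `Cc1ccc2c(NCc3ccc(NC(=O)C4CCN(Cc5ccccc5)CC4)cc3)nc(N(C)CCCN(C)C)nc2c1`; in this assay compound 2 gives only a limit, > 8620 nM
- compound 3, `Cc1ccc2c(NCc3ccc(NC(=O)C4CCN(Cc5ccccc5)CC4)cc3)nc(N(C)CCN(C)C)nc2c1`; in this assay compound 3 gives only a limit, > 8830 nM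

Compound 1 stands at the limit of > 8320 nM in this assay, at which 1 of the 3 values shown sits, and no number below that limit is known for it. Compound 2 stands at the limit of > 8620 nM in this assay, at which 1 of the 3 values shown sits. Compound 3 stands at the limit of > 8830 nM in this assay, at which 1 of the 3 values shown sits. For the measured compounds named here, the one step between measured compounds, a step that the two limits leave unreadable from compound 2 to compound 3, cannot be read, since both ends are limits.

Compound 4, `Cc1ccc2c(NCc3ccc(NC(=O)C4CCN(C)CC4)cc3)nc(N(C)C)nc2c1`, differs from compound 1 by methyl in place of cyclohexyl on an amine nitrogen in a ring. Going by the values given here, none of the measured steps touches the group on this ring nitrogen, so no measured step bears on the change, and all three measured compounds sit at limits in this assay. The step that the limit leaves unreadable from compound 1 to compound 4 is therefore expected to stay unreadable, with compound 4 most likely giving a limit again. For compound 4 the estimate is 15000 nM, in a range from 6000 nM to 40000 nM.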

Compound 4, half-maximal inhibitory concentration: > 17300 nM
Compound 4: only a limit was reported; the forecaster's own chance of this, stated with the estimate: 80%; middle value at least 1.1-fold (0.06 log units) from the limit.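

In this assay compound 4 gives only a limit, > 17300 nM; compound 1 also sits at a limit, so the step between them cannot be read. The compounds shown leave open whether methyl in place of cyclohexyl changes the true inhibitory concentration at all.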